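Swapping the benzyl group on a triazole ether core

The compounds below may be only part of what the source reports. "The series", "measured", "known", "first", "only" and "open" are said of these compounds alone.

Compound 1 `Cc1ccccc1Cn1cc(COc2ccc3c(=O)ccoc3c2)nn1` stands lowest of three numbers in a functional assay on HeLa cells (Homo sapiens) for cytotoxicity, read by MTT assay, with a stated time of 48 h (a lower number here means a stronger inhibitor, a higher number a weaker inhibitor), where compound 1 gives 15300 nM. Compound 2 `O=c1ccoc2cc(OCc3cn(Cc4ccc(Cl)cc4)nn3)ccc12` gives 37600 nM in this assay, and compound 3 `C#CCOc1ccc2c(=O)ccoc2c1`, which lacks the whole benzyl-triazole arm, gives 64700 nM. Among the measured compounds shown here, the one measured step that changes the same part of the molecule is a 2.5-fold higher number from compound 1 to compound 2 (0.39 log units; beyond the scatter).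

Compound 4 `N#Cc1cccc(Cn2cc(COc3ccc4c(=O)ccoc4c3)nn2)c1` differs from compound 1 in the same place: 3-cyanophenyl in place of 2-methylphenyl on a saturated chain carbon bound to an aromatic nitrogen. The step to compound 2 shows that replacing 2-methylphenyl by another substituted phenyl on that carbon can weaken inhibition modestly, though a single example with a different group is thin ground. A small rise in this assay is therefore expected, of about the size a 1.6-fold higher number from compound 1 to compound 4 (0.21 log units; within the scatter), with a wide margin. Compound 4 is estimated at 25000 nM, within a range from 10000 nM to 65000 nM.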

Compound 4, half-maximal inhibitory concentration: > 100000 nM
Compound 4: no number, only a limit (the forecaster's own chance of this, stated with the estimate: 10%); at least 4.0-fold (0.60 log units) between middle value and limit.
By their numbers in this assay, from the lowest: compound 1; then compounds 2 and 3 (each within the scatter of the next). At a limit, above all of these: compound 4.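

The value for compound 4 is a limit and not a number: the limit of > 100000 nM in this assay, at which 1 of the 4 values shown sits. Replacing 2-methylbenzyl with 3-cyanobenzyl gives an at least 6.5-fold higher number from compound 1 to compound 4 (0.81 log units; beyond the scatter), and replacing 4-chlorophenyl with 3-cyanophenyl gives an at least 2.6-fold higher number from compound 2 to compound 4 (0.42 log units; beyond the scatter). The group on the saturated chain carbon bound to an aromatic nitrogen can therefore shift the result by more than the first step suggested, even when one substituted phenyl simply replaces another.

These compounds cannot separate the effect of the nitrile itself from the effect of its place on the ring, and they offer no measured property that would explain the change. Going by these compounds, it also remains open what a benzyl group with no substituent, or a benzyl group carrying an amine, would give in this assay.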